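The source may report more compounds than this note shows. Statements on the series, on what has been measured and on what is new or still open speak of the compounds shown alone.

In an assay on Sf9 cells for inhibition of histone deacetylase 11 (Homo sapiens), read by fluorescence, tested at 0.5 uM (on this read-out higher numbers stand for more inhibition at the one concentration tested (going by the name of the read-out) and lower numbers for less inhibition), two compounds have been measured so far, and neither rises above the lower limit of the read-out. Compound 1 `O=C(NO)c1cccc(-c2cn([C@@H]3C[C@@H](CO)N(CCCc4ccccc4)C3)nn2)c1` gives only a limit, < 10%. Compound 2 `O=C(NO)c1ccc(-c2cn([C@H]3C[C@@H](CO)N(CCCc4ccccc4)C3)nn2)cc1` likewise gives only a limit, < 10%. Both values sit at the limit of < 10% in this assay, at which 2 of the 2 values shown sit. Compound 3 `O=C(NO)c1ccc(-c2cn([C@@H]3C[C@@H](CO)N(CCCc4ccccc4)C3)nn2)cc1` has not been measured yet; (the two compounds have the same atoms and bonds and differ only in configuration as drawn: 1 of 2 stereo elements differ; a stereocentre at a saturated ring carbon is drawn S in compound 2 and R in compound 3). Within the data shown here, no measured pair shows what such a change does here, so the step is expected to stay within the scatter, with a step that the limit leaves unreadable from compound 2 to compound 3. Compound 3 is accordingly estimated at 5%, within 0% to 15%, and will most likely again be reported only as a limit.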

Compound 3, a percentage reported as inhibition, at one concentration (the size of the read-out at that concentration, not a potency): 14%
Beside the measured number, compound 3's estimate is 9 percentage points below it, within the range that was stated.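

Only compound 3 gives a number in this assay, 14%. Inverting one stereocentre at a saturated ring carbon gives a number at least 4 percentage points higher from compound 2 to compound 3 (that floor lies within the scatter), and 4-(hydroxycarbamoyl)phenyl in place of 3-(hydroxycarbamoyl)phenyl gives a number at least 4 percentage points higher from compound 1 to compound 3 (that floor lies within the scatter), so neither change is shown to matter. The other two compounds stay at a limit: the limit of < 10% in this assay, at which 2 of the 3 values shown sit.

Left open is how far compounds 1 and 2 actually lie from compound 3, and what the other stereocentre contributes. The compounds shown also leave open whether a carboxylic acid in place of the hydroxymethyl group, or a longer chain in place of the 3-phenylpropyl group, would alter the reading.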